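Furan for Thiazole on a Lengthened Polyene Ester

The source may hold more compounds than are shown below. What is called first, only, known or untested is meant among the compounds shown, and "the series" means these compounds.

Compound 1, `CCOC(=O)/C=C/C=C/C=C/c1nccs1`: in a functional assay on Raji cells (Homo sapiens) for cytotoxicity, with a stated time of 72 h (on this read-out higher numbers stand for weaker inhibition and lower numbers for stronger inhibition), compound 1 gives 4350 nM.
Compound 2, `CCOC(=O)/C=C/C=C/C=C/C=C/c1nccs1`: in this assay compound 2 reaches only a limit of the assay, > 10000 nM.
Compound 3, `CCOC(=O)/C=C/C=C/C=C/c1ccco1`: in this assay compound 3 likewise stops at a limit, > 10000 nM.

Compound 1 and compound 3 share one core and differ in a single place: furan-2-yl in place of 1,3-thiazol-2-yl on a double-bonded chain carbon bound to a double-bonded chain carbon. That change brought an at least 2.2-fold higher number from compound 1 to compound 3 (0.36 log units; beyond the scatter), so the furan bearer inhibits the cells more weakly than the thiazole bearer, at least to a modest degree.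

Compound 2 carries the same thiazole on a longer chain than compound 1; the difference between the two cores is not broken down here. Compound 4, `CCOC(=O)/C=C/C=C/C=C/C=C/c1ccco1`, has not been measured. It stands to compound 2 exactly as compound 3 stands to compound 1: furan-2-yl in place of 1,3-thiazol-2-yl on a double-bonded chain carbon bound to a double-bonded chain carbon, the same change at the same place.

The earlier step only weakened inhibition, and compound 2 already sits at a limit. Compound 4 is therefore expected to sit at a limit too, the estimated step that the limit leaves unreadable from compound 2 to compound 4 being mostly a statement of direction, because the limit of > 10000 nM in this assay, at which 2 of the 3 values shown sit, leaves no measurable room to show a further rise. Compound 4 is expected to give about 30000 nM, plausibly between 10000 nM and 100000 nM.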

Compound 4, half-maximal inhibitory concentration: > 10000 nM
Compound 4: a limit, no number; the forecaster's own chance of this, stated with the estimate: 90%; the middle value is on the limit's open side.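

Compound 2 and compound 4 both stop at a limit of the assay, so no step can be read between them, because neither gives a number: the limit of > 10000 nM in this assay, at which 3 of the 4 values shown sit.

The compounds shown leave open whether furan-2-yl in place of 1,3-thiazol-2-yl weakens inhibition on the longer chain as it did on the shorter one, and how weak compound 2 and compound 4 really are.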